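A few compounds are considered here, and "the series" means these few. Any claim that something is new, unique, unknown or untested is made for them only; others in the source may bear on it.

Measured in an ADME assay on CHO-K1 cells (Cricetulus griseus) for cytotoxicity, read by MTT assay, with a stated time of 24 h; on this read-out higher numbers stand for lower toxicity in this test and lower numbers for higher toxicity in this test:
compound 1 `S=C(Nc1ccccc1)Nc1ccc2[nH]ccc2c1`: 337000 nM
compound 2 `Oc1ccccc1NC(=S)Nc1ccc2[nH]ccc2c1`: 509000 nM
compound 3 `Oc1cccc(NC(=S)Nc2ccc3[nH]ccc3c2)c1`: 977000 nM

Compound 1 sits at the low end of this small set, with a 1.5-fold higher number from compound 1 to compound 2 (0.18 log units; within the scatter) and a 2.9-fold higher number from compound 1 to compound 3 (0.46 log units; beyond the scatter). Compound 4 `Oc1ccc(NC(=S)Nc2ccc3[nH]ccc3c2)cc1` is still to be measured and carries hydroxy in place of hydrogen on an aromatic carbon, hydroxy in place of hydrogen on an aromatic carbon. Both measured steps are this same exchange made at other places, and both give higher numbers, so they bear directly on it. A modest upward step of similar size is therefore expected in this assay, although it may prove hard to separate from the scatter. The estimated step is a 1.9-fold higher number from compound 1 to compound 4 (0.29 log units; within the scatter). For compound 4 the estimated value is 650000 nM, with an expected range from 340000 nM to 1250000 nM.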

Compound 4, concentration lethal to 50% of the cells: 848000 nM
Estimate against measurement, compound 4: 1.3-fold (0.12 log units) below; the range from low to high includes it.
By their numbers in this assay, from the lowest: compounds 1, 2, 4 and 3 (each within the scatter of the next, the first and the last beyond it).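

In this assay, hydroxy in place of hydrogen on an aromatic carbon, para to a large group, gives a 2.5-fold higher number from compound 1 to compound 4 (0.40 log units; beyond the scatter). This place therefore joins that of compound 3 in giving a step beyond the scatter, whereas the step to compound 2 stays within it. Nothing available explains the size of this step.

The compounds shown leave open whether a methoxy group, an amine or a carboxylic acid at this same place would give a similar step. They also leave open whether a second hydroxy on this ring would add to it.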